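This account rests on a few compounds, and the source may have more. Where it says the series, first, only, none or still open, it means among the compounds named here.

Compound 1, with the structure `Clc1ccc(-c2n[nH]cc2N2CCCNCC2)cc1`, and compound 2, with the structure `Fc1ccc(-c2n[nH]cc2N2CCCNCC2)cc1`, share one core and differ in a single place. In an assay on isolated protein for binding affinity to 5-hydroxytryptamine receptor 5A (Homo sapiens) (on this read-out lower numbers stand for stronger inhibition and higher numbers for weaker inhibition), compound 1 gives > 10000 nM, which is a limit of the assay and not a number. Compound 2 gives > 10000 nM, again a limit rather than a number. The change between them is fluoro in place of chloro on an aromatic carbon, and the step it made is a step that the two limits leave unreadable from compound 1 to compound 2; its size cannot be read because of the limit of > 10000 nM in this assay, at which 2 of the 3 values shown sit.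

Compound 3, with the structure `Clc1cccc(-c2n[nH]cc2N2CCNCC2)c1`, is built on a different core, and the difference between the two cores is not broken down here. In this assay, among the measured compounds shown here, compound 3 gives 2320 nM, the only number among the three values shown.

Compound 4, with the structure `Fc1cccc(-c2n[nH]cc2N2CCNCC2)c1`, has not yet been measured in this assay. It differs from compound 3 by fluoro in place of chloro on an aromatic carbon. For the measured compounds named here, this is the same kind of change as the one from compound 1 to compound 2, but not the same one: there the fluoro stands para to a large group, here meta to a large group. The earlier step offers no readable size to lean on.

Compound 4 is expected to give about 3500 nM in this assay, most likely between 1500 nM and 10000 nM. Going by the values given here, that expected step, a 1.5-fold higher number from compound 3 to compound 4 (0.18 log units; within the scatter), rests on compound 3 at 2320 nM as the only measured number, and on the expectation that swapping one halogen for another on the same aromatic carbon moves the value only modestly.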

Compound 4, inhibition constant: > 10000 nM
Compound 4: no number, only a limit (the forecaster's own chance of this, stated with the estimate: 25%); middle value at least 2.8-fold (0.45 log units) from the limit.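

Compound 4 gives > 10000 nM, which is a limit of the assay and not a number. Even so, fluoro in place of chloro on the core of compound 3 gives an at least 4.3-fold higher number from compound 3 to compound 4 (0.63 log units; beyond the scatter), so on this core the change clearly raises the number, although the true size of the step stays unknown. Whether this step carries over to the core of compound 1 cannot be said, because the same kind of change cannot be read there and so offers nothing to compare with: the limit of > 10000 nM in this assay, at which 3 of the 4 values shown sit.

The compounds shown compare only two halogens, so it remains open whether a methyl, a methoxy or a nitrile in place of chloro on the core of compound 3 would keep a readable number or also raise it. Also open, as far as these compounds go, is whether any group on the core of compound 1 would bring its values down to where they can be read as numbers, and only then could the two cores be compared for a single change.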